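A few compounds are considered here, and "the series" means these few. Any claim that something is new, unique, unknown or untested is made for them only; others in the source may bear on it.

Measured in a functional assay on MCF7 cells (Homo sapiens) for antiproliferative activity, read by MTT assay, with a stated time of 48 h; on this read-out lower numbers stand for stronger inhibition and higher numbers for weaker inhibition:
- Compound 1 `COc1cc(-c2nnc3c(OCC(F)(F)F)cc(-c4ccc5[nH]ccc5c4)cn23)cc(OC)c1OC`: 608 nM
- Compound 2 `COc1cc(-c2nnc3c(OC4COC4)cc(-c4ccc5c(ccn5C)c4)cn23)cc(OC)c1OC`: 1900 nM

Compound 2 holds the higher of these two numbers, and its gap to compound 1 lies beyond the usual scatter. Compound 3 `COc1cc(-c2nnc3c(OCC(F)(F)F)cc(-c4ccc5c(ccn5C)c4)cn23)cc(OC)c1OC` has 2,2,2-trifluoroethyl in place of oxetan-3-yl on an oxygen on an aromatic ring. For the measured compounds named here, no measured pair isolates this change. Compound 1, at 608 nM, carries the same 2,2,2-trifluoroethyl group, but it also differs from compound 2 elsewhere, so it offers only a loose guide. On that basis, a moderate move toward a lower number is expected in this assay, with an estimated 2.4-fold lower number from compound 2 to compound 3 (0.38 log units; beyond the scatter). That move may not clear the scatter by much. The expected value for compound 3 is 800 nM, with an estimated range of 280 nM to 2200 nM.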

Compound 3, half-maximal inhibitory concentration: 382 nM
Beside the measured number, compound 3's estimate is 2.1-fold (0.32 log units) above it, and the stated range covers the measured number.
By their numbers in this assay, from the lowest: compounds 3 and 1 (each within the scatter of the next); then compound 2.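

In this assay, the change from oxetan-3-yl to 2,2,2-trifluoroethyl on an oxygen on an aromatic ring now stands alone in a pair and gives a 5.0-fold lower number from compound 2 to compound 3 (0.70 log units; beyond the scatter), beyond the scatter, so the gap between these two groups at this oxygen no longer rests on a comparison that also differs elsewhere. Methyl in place of hydrogen on an aromatic nitrogen gives a 1.6-fold lower number from compound 1 to compound 3 (0.20 log units; within the scatter), within the scatter, so with 2,2,2-trifluoroethyl on the oxygen this second change cannot be told from no change. Nothing available speaks to the reason for either step.

The compounds shown leave open whether a plain ethyl or a cyclobutyl group on this oxygen would read like 2,2,2-trifluoroethyl or like oxetan-3-yl in this assay. They also leave open whether the methyl on the aromatic nitrogen would read the same with oxetan-3-yl on the oxygen.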